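Amide variation on the oxadiazolyl-azetidine series

The compounds below may be only part of what the source reports. "The series", "measured", "known", "first", "only" and "open" are said of these compounds alone.

Measured so far in an assay on HEK293 cells for positive allosteric modulation of metabotropic glutamate receptor 5 (Homo sapiens), read by FLIPR; a lower number here means that less compound is needed, a higher number that more compound is needed for the effect:
compound 1 `O=C(c1ccc(F)c(F)c1)N1CC(c2nc(-c3cccc(F)c3)no2)C1` gives 3200 nM
compound 2 `O=C([C@@H]1CC2CCC1C2)N1CC(c2nc(-c3ccccc3)no2)C1` gives 400 nM
compound 3 `O=C(C1CCC(F)(F)CC1)N1CC(c2nc(-c3cccc(F)c3)no2)C1` gives 520 nM

Compound 3 stands second highest of the three numbers; the gap to compound 2 is within the scatter, whereas a 6.2-fold lower number from compound 1 to compound 3 (0.79 log units; beyond the scatter) lies beyond it. For the measured compounds named here, the only step measured in one place is that one, and it concerns a different group than the one now exchanged. Compound 4 `O=C([C@@H]1CC2CCC1C2)N1CC(c2nc(-c3cccc(F)c3)no2)C1` carries the change (a group of 7 heavy atoms (7 carbon; 2 five-membered non-aromatic rings of carbon only) in place of a group of 8 heavy atoms (6 carbon, 2 fluorine; one six-membered non-aromatic ring of carbon only), on a carbonyl carbon). Compound 2 already bears the same group of 7 heavy atoms and, with an unsubstituted phenyl, gives a value within the scatter of compound 3. No step beyond the scatter is therefore expected, and a 1.4-fold lower number from compound 3 to compound 4 (0.14 log units; within the scatter) is estimated as essentially flat. For compound 4 the expected value is 380 nM, with a range from 150 nM to 950 nM.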

Compound 4, half-maximal effective concentration: 100 nM
Estimate against measurement, compound 4: 3.8-fold (0.58 log units) above; the whole stated range lies above it.
By their numbers in this assay, from the lowest: compound 4; then compounds 2 and 3 (each within the scatter of the next); then compound 1.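

In this assay, with the aromatic fluoro held constant, the group of 7 heavy atoms on the carbonyl carbon gives a 5.2-fold lower number from compound 3 to compound 4 (0.72 log units; beyond the scatter) in place of 4,4-difluorocyclohexyl and a 32-fold lower number from compound 1 to compound 4 (1.51 log units; beyond the scatter) in place of 3,4-difluorophenyl. With that group held constant, fluoro in place of hydrogen on an aromatic carbon gives a 4.0-fold lower number from compound 2 to compound 4 (0.60 log units; beyond the scatter), so the closeness of compound 2 and compound 3 conceals two separate differences. No measurement at hand accounts for either change.

The compounds shown leave open whether the fluoro step carries over to compounds with 4,4-difluorocyclohexyl on the carbonyl carbon. Also open, from the compounds shown here alone, is how chloro or methoxy in place of that fluoro, or tert-butyl on the carbonyl carbon, would read out.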